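Bromo step on the fluoro compound

The compounds below may be only part of what the source reports. "The series", "measured", "known", "first", "only" and "open" are said of these compounds alone.

In a functional assay on HeLa cells (Homo sapiens) for antiproliferative activity, read by MTT assay, with a stated time of 48 h (a lower number here means a stronger inhibitor, a higher number a weaker inhibitor), compound 1 `c1ccc(-c2nn(-c3ccccc3)cc2-c2nc3ccccc3[nH]2)cc1` gives 1550 nM and compound 3 `Fc1ccc(-c2nn(-c3ccccc3)cc2-c2nc3ccccc3[nH]2)cc1` gives 2330 nM within the scatter of each other, while compound 2 `O=C(OCc1ccccc1)c1ccc2[nH]c(-c3cn(-c4ccccc4)nc3-c3ccccc3)nc2c1` gives 21300 nM as the highest number of the three. Next comes compound 4 `Fc1ccc(-c2nn(-c3ccccc3)cc2-c2nc3cc(Br)ccc3[nH]2)cc1` with the change bromo in place of hydrogen on an aromatic carbon and bromo in place of hydrogen on an aromatic carbon. Within the data shown here, two measured steps bear on it. Fluoro in place of hydrogen gave a 1.5-fold higher number from compound 1 to compound 3 (0.18 log units; within the scatter) and benzyloxycarbonyl in place of hydrogen gave a 14-fold higher number from compound 1 to compound 2 (1.14 log units; beyond the scatter) but that group is a poor match for a single bromine. In this assay the estimate is a 1.5-fold higher number from compound 3 to compound 4 (0.18 log units; within the scatter) so no step beyond the scatter is expected, though a rise remains possible. For compound 4 the expected value is 3500 nM with an estimated range from 1200 nM to 10000 nM as its ends.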

Compound 4, half-maximal inhibitory concentration: 4940 nM
Compound 4: middle estimate off by 1.4-fold (0.15 log units), on the low side; the measured number falls inside the stated range.
By their numbers in this assay, from the lowest: compounds 1 and 3 (each within the scatter of the next); then compound 4; then compound 2.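

In this assay bromo in place of hydrogen on the six-membered carbon ring of the fused system gives a 2.1-fold higher number from compound 3 to compound 4 (0.33 log units; beyond the scatter) as a modest step, on the fluoro background. Until now the only substituent read on that fused system was benzyloxycarbonyl, with a 14-fold higher number from compound 1 to compound 2 (1.14 log units; beyond the scatter) as its step, and a single bromine now also moves the number upward there. Nothing measured here accounts for the rise.

Open, as far as these compounds go, is whether an amine or a carboxylic acid on that ring carbon would lower the number. Also open, from the compounds shown here alone, is whether bromo gives a similar step without the fluoro.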